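Substituent swap at the aryl position in the amide series

The source may report more compounds than this note shows. Statements on the series, on what has been measured and on what is new or still open speak of the compounds shown alone.

Compound 3 `CC(C)C[C@H](N)CN(C(=O)[C@@H]1C[C@H]1c1ccccc1)c1ccc(C2=CCCCC2)cc1` sits at 1200 nM in a functional assay for agonist activity at G protein-coupled receptor 88 (Homo sapiens), read by HTRF and cAMP accumulation (on this read-out higher numbers stand for an effect only at larger amounts of compound and lower numbers for an effect already at smaller amounts), level with compound 1 `CC(C)C[C@H](N)CN(C(=O)[C@@H]1C[C@H]1c1ccccc1)c1ccc(-c2ccsc2)cc1` at 1200 nM; together these two give the lowest numbers among the three measured compounds. Compound 2 `CC(C)C[C@H](N)CN(C(=O)[C@@H]1C[C@H]1c1ccccc1)c1ccc(C2=CCCCCC2)cc1` gives 2100 nM. All steps among them are small: a 1.8-fold higher number from compound 1 to compound 2 (0.24 log units; within the scatter), no change at the digits printed from compound 1 to compound 3 (within the scatter) and a 1.8-fold lower number from compound 2 to compound 3 (0.24 log units; within the scatter), each within the scatter. So far the group on this aromatic carbon has been exchanged between a five-membered aromatic ring and two non-aromatic rings of carbon only without a shift beyond the scatter.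

Compound 4 `COc1ccc(-c2ccc(N(C[C@@H](N)CC(C)C)C(=O)[C@@H]3C[C@H]3c3ccccc3)cc2)cc1` is not yet measured. It differs from compound 3 as follows: 4-methoxyphenyl in place of cyclohex-1-en-1-yl on an aromatic carbon. The change again alters only the group on the aromatic carbon, para to a large group, and brings an aromatic ring back in, as compound 1 already had. Given the flat steps from compound 1 through compound 3, no step beyond the scatter is expected in this assay; the expected step of a 1.1-fold higher number from compound 3 to compound 4 (0.03 log units; within the scatter) is set close to zero. For compound 4 the expected value is 1300 nM, with a range from 500 nM to 3500 nM.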

Compound 4, half-maximal effective concentration: 330 nM
For compound 4 the middle estimate is 3.9-fold (0.60 log units) above the measured one; the whole stated range lies above it.
By their numbers in this assay, from the lowest: compound 4; then compounds 1, 3 and 2 (each within the scatter of the next).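

The group on this aromatic carbon can move the number beyond the scatter: 4-methoxyphenyl gives a 3.6-fold lower number from compound 3 to compound 4 (0.56 log units; beyond the scatter) against cyclohex-1-en-1-yl, a 3.6-fold lower number from compound 1 to compound 4 (0.56 log units; beyond the scatter) against thiophen-3-yl and a 6.4-fold lower number from compound 2 to compound 4 (0.80 log units; beyond the scatter) against cyclohept-1-en-1-yl. The flat picture from compounds 1, 2 and 3 therefore does not hold for the position as a whole. An aromatic ring here is not enough by itself, as compound 1 also carries one and still lies beyond the scatter from compound 4.

Going by these compounds, whether the step belongs to the six-membered aromatic ring or to its methoxy group stays open; a plain phenyl would separate the two. Nothing at hand explains the step.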